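Fluoro on the central ring of compound 2: expectation

The compounds below may be only part of what the source reports. "The series", "measured", "known", "first", "only" and "open" are said of these compounds alone.

Within the data shown here, compound 2 `O=C(Nc1ccc(Oc2ccnc3[nH]ccc23)cc1)c1cc(-c2ccccc2)ncn1` holds the lower of the two numbers so far in a functional assay on PC-3 cells (Homo sapiens) for cytotoxicity, read by MTT assay, with a stated time of 72 h; on this read-out higher numbers stand for weaker inhibition and lower numbers for stronger inhibition. In this assay compound 2 gives 240 nM. Among the measured compounds shown here, its only measured neighbour is compound 1 `COc1ccc(-c2cc(C(=O)Nc3ccc(Oc4ccnc5[nH]ccc45)cc3)ncn2)cc1`, which in this assay gives 9830 nM; the step of a 41-fold lower number from compound 1 to compound 2 (1.61 log units; beyond the scatter) is the one measured change, hydrogen in place of methoxy on an aromatic carbon, and it is a different change at a different place from the one now in question.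

Compound 3 `O=C(Nc1ccc(Oc2ccnc3[nH]ccc23)c(F)c1)c1cc(-c2ccccc2)ncn1` differs from compound 2 by fluoro in place of hydrogen on an aromatic carbon. For the measured compounds named here, no measured step touches this group or this place, so the step from compound 1 to compound 2 does not bear on it directly; it shows only that a single small change can move the number a great deal. With nothing in the data to argue for either direction, the expectation is no step beyond the scatter, no change at the digits printed from compound 2 to compound 3 (within the scatter), with a wide range to cover the uncertainty. Compound 3 is therefore estimated at 240 nM in this assay, between 70 nM and 800 nM.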

Compound 3, half-maximal inhibitory concentration: 40 nM
The estimate for compound 3 lay 6.0-fold (0.78 log units) above the measured number, and the stated range ends above it.
By their numbers in this assay, from the lowest: compound 3; then compound 2; then compound 1.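

In this assay, fluoro in place of hydrogen on an aromatic carbon, ortho to a large group and meta to a large group, gives a 6.0-fold lower number from compound 2 to compound 3 (0.78 log units; beyond the scatter), so this place on the six-membered aromatic ring of carbon only is one where a single fluorine atom goes with a lower number. Among these compounds, the earlier step, a 41-fold lower number from compound 1 to compound 2 (1.61 log units; beyond the scatter), concerned methoxy at a different place and showed a lower number on going to hydrogen; the new step shows a lower number on going from hydrogen to a substituent, so the loss of a group is not the only single change that lowers the number. Nothing available bears on why the number moves at this place.

The compounds shown leave open whether the step belongs to fluoro itself or would also appear with chloro, methyl, methoxy or an amine at this place. They also leave open whether fluoro here gives a step of similar size when the methoxy of compound 1 is present, and whether the step holds in any read-out other than this assay as used here.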